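Swapping the Tail Amine of Compound 1

A few compounds are considered here, and "the series" means these few. Any claim that something is new, unique, unknown or untested is made for them only; others in the source may bear on it.

Compound 1 `COc1cc2c(Oc3ccc(NC(=O)c4nccc(-c5ccc(C)cc5)n4)cc3F)ccnc2cc1OCCCN1CCN(C)CC1` belongs to a set of three amides built on one shared core, differing only in the aromatic group at the far end of the amide. In a functional assay on MKN-45 cells (Homo sapiens) for cytotoxicity, read by MTT assay, with a stated time of 72 h (a higher number here means a weaker inhibitor, a lower number a stronger inhibitor), compound 1 gives 340 nM, the second highest of the three numbers. Compound 2 `COc1cc2c(Oc3ccc(NC(=O)c4nccc(-c5ccc(F)cc5)n4)cc3F)ccnc2cc1OCCCN1CCN(C)CC1` gives 90 nM in this assay, and compound 3 `COc1cc2c(Oc3ccc(NC(=O)c4nccc(-c5ccc(F)cc5F)n4)cc3F)ccnc2cc1OCCCN1CCN(C)CC1` gives 440 nM. The measured steps are a 3.8-fold lower number from compound 1 to compound 2 (0.58 log units; beyond the scatter), a 1.3-fold higher number from compound 1 to compound 3 (0.11 log units; within the scatter) and a 4.9-fold higher number from compound 2 to compound 3 (0.69 log units; beyond the scatter), and all three concern that aromatic group alone.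

Compound 4 `COc1cc2c(Oc3ccc(NC(=O)c4nccc(-c5ccc(C)cc5)n4)cc3F)ccnc2cc1OCCCN1CCCC1` differs from compound 1 elsewhere: pyrrolidin-1-yl in place of 4-methylpiperazin-1-yl on a saturated chain carbon, three bonds along the chain from an oxygen on an aromatic ring. Among the compounds with values here, none of the measured steps touches this chain end, so no measured step bears directly on the change; the data simply contain no comparison of this kind. With nothing to point either way, compound 4 is expected to sit close to compound 1, with a step of no change at the digits printed from compound 1 to compound 4 (within the scatter) that is expected to stay within the scatter. The estimate for compound 4 in this assay is therefore 340 nM, expected to lie between 110 nM and 1000 nM.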

Compound 4, half-maximal inhibitory concentration: 240 nM
The estimate for compound 4 lay 1.4-fold (0.15 log units) above the measured number; the range from low to high includes it.
By their numbers in this assay, from the lowest: compound 2; then compounds 4, 1 and 3 (each within the scatter of the next).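

Placing pyrrolidin-1-yl where compound 1 carries 4-methylpiperazin-1-yl gives, in this assay, a 1.4-fold lower number from compound 1 to compound 4 (0.15 log units; within the scatter) and is the first reading at the chain end, as every earlier step concerned the aromatic group at the far end of the amide. In this assay, a five-membered ring with one hetero atom stands in for a six-membered ring with two hetero atoms, and compounds 1 and 4 cannot be told apart. Nothing shown here offers an explanation for this result.

The compounds shown leave open whether the same swap would hold with the 4-fluorophenyl group of compound 2 in place of the 4-methylphenyl group. They also leave open what a morpholine or a dimethylamino group at the chain end, or a shorter chain, would give.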